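This account rests on a few compounds, and the source may have more. Where it says the series, first, only, none or still open, it means among the compounds named here.

Measured so far:
Compound 1, `Oc1ccc(C2CC(c3ccccc3O)=NN2c2cccc(Cl)c2)cc1F`: 25.2%
Compound 2, `Oc1ccccc1C1=NN(c2cccc(Cl)c2)C(c2cc(F)c(O)c(F)c2)C1`: 45.2%

Among the compounds with values here, in an assay on isolated protein for inhibition of protein kinase C iota type (Homo sapiens), tested at 20 uM (on this read-out higher numbers stand for more inhibition at the one concentration tested (going by the name of the read-out) and lower numbers for less inhibition), compound 2 gives the higher of the two numbers, and the only measured step, a number 20 percentage points higher from compound 1 to compound 2 (beyond the scatter), separates it from compound 1. Compound 3, `Oc1ccccc1C1=NN(c2cccc(Cl)c2)C(c2ccc(O)c(F)c2F)C1`, is the next compound to be measured. It differs from compound 2 in that (2,3-difluoro-4-hydroxyphenyl in place of 3,5-difluoro-4-hydroxyphenyl on a saturated ring carbon). Within the data shown here, the one measured step concerns a fluoro put in place of hydrogen, whereas the change to compound 3 keeps the same atoms and only joins them differently, so that step bears on it only loosely. Among the measured compounds shown here, with no step of the same kind to lean on, the expectation for compound 3 is a change of a number 5.2 percentage points lower from compound 2 to compound 3 (within the scatter) in this assay, which is within the usual scatter. Compound 3 is therefore estimated at 40%, with a range from 20% to 60%.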

Compound 3, a percentage reported as inhibition, at one concentration (the size of the read-out at that concentration, not a potency): 39.2%
Compound 3: the middle estimate sits 0.8 percentage points above what was measured; the measured number falls inside the stated range.
By their numbers in this assay, from the lowest: compound 1; then compounds 3 and 2 (each within the scatter of the next).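

In this assay, 2,3-difluoro-4-hydroxyphenyl in place of 3,5-difluoro-4-hydroxyphenyl on the saturated ring carbon gives a number 6 percentage points lower from compound 2 to compound 3 (within the scatter), so no difference between these two arrangements of the same atoms can be claimed. Fluoro in place of hydrogen on an aromatic carbon now appears in a second location on this ring, and it gives a number 14 percentage points higher from compound 1 to compound 3 (beyond the scatter), which agrees in direction with a number 20 percentage points higher from compound 1 to compound 2 (beyond the scatter) and has no counterexample among these three compounds. No supporting measurement is available to explain these numbers.

The compounds shown leave open whether a different group on this ring, such as methoxy or an amine, would give a similar reading. They also leave open how these compounds would compare as full potencies, since each number comes from a single concentration.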